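Moving the bromine: from compound 1 toward compound 4

A few compounds are considered here, and "the series" means these few. Any claim that something is new, unique, unknown or untested is made for them only; others in the source may bear on it.

Measured so far:
compound 1, `CC1(C)[C@H]2CC[C@]1(C)N(Cc1cn(-c3ccc(C#N)cc3)nn1)C(=O)C2`: 250 nM
compound 2, `CC1(C)[C@H]2CC[C@]1(C)N(Cc1cn(-c3ccc(O)cc3)nn1)C(=O)C2`: 100 nM
compound 3, `CC1(C)[C@H]2CC[C@]1(C)N(Cc1cn(-c3ccc(Br)cc3)nn1)C(=O)C2`: 200 nM

In a functional assay on PANC-1 cells (Homo sapiens) for inhibition, read by MTT assay, with a stated time of 24 h (on this read-out higher numbers stand for weaker inhibition and lower numbers for stronger inhibition), compound 1 gives the highest of the three numbers, so among these it inhibits least. Compound 4, `CC1(C)[C@H]2CC[C@]1(C)N(Cc1cn(-c3cccc(Br)c3)nn1)C(=O)C2`, is not yet measured. It differs from compound 1 by 3-bromophenyl in place of 4-cyanophenyl on an aromatic nitrogen. The closest guide is the step of a 1.3-fold lower number from compound 1 to compound 3 (0.10 log units; within the scatter), which swaps the same cyano for bromo, though compound 3 does not carry a 3-bromophenyl group. The steps of a 2.5-fold lower number from compound 1 to compound 2 (0.40 log units; beyond the scatter) and a 2.0-fold higher number from compound 2 to compound 3 (0.30 log units; within the scatter) show the whole spread so far is small. A step of a 1.3-fold lower number from compound 1 to compound 4 (0.10 log units; within the scatter) is therefore expected, not beyond the scatter. Compound 4 is estimated at 200 nM, within 100 nM to 400 nM.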

Compound 4, half-maximal inhibitory concentration: 90 nM
Compound 4: middle estimate off by 2.2-fold (0.35 log units), on the high side, and the stated range ends above it.
By their numbers in this assay, from the lowest: compounds 4, 2, 3 and 1 (each within the scatter of the next, the first and the last beyond it).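

The earlier compounds shown here changed only the group in the 4-substituted phenyl ring, whereas here the bromine itself moves, and in this assay that move alone gives a 2.2-fold lower number from compound 3 to compound 4 (0.35 log units; beyond the scatter). So with the same atoms, the place of the bromine on this phenyl ring changes the number beyond the scatter. The 3-bromophenyl group in place of 4-cyanophenyl gives a 2.8-fold lower number from compound 1 to compound 4 (0.44 log units; beyond the scatter), while in place of 4-hydroxyphenyl it gives a 1.1-fold lower number from compound 2 to compound 4 (0.05 log units; within the scatter), which leaves those two compounds level. On these data alone, whether a 3-aminophenyl or 3-carboxyphenyl group would match the 3-bromophenyl group remains open. Nothing measured here explains why moving the bromine shifts the number.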